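Configuration Reversal at the Lactone Ring Carbon

A few compounds are considered here, and "the series" means these few. Any claim that something is new, unique, unknown or untested is made for them only; others in the source may bear on it.

Measured compounds:
compound 1, `C=C1C(=O)OC[C@@H]1CCOC(=O)Nc1ccc(CCCC)cc1`, 1230 nM
compound 2, `C=C1C(=O)OC[C@H]1CCOC(=O)Nc1ccc(Br)cc1`, 350 nM

Of the compounds shown here, two have so far been tested in a functional assay on RAW264.7 cells (Mus musculus) for inhibition, with a stated time of 30 min; on this read-out higher numbers stand for weaker inhibition and lower numbers for stronger inhibition. Compound 1 gives 1230 nM, and compound 2 gives 350 nM. Among the measured compounds shown here, of these two numbers, compound 2 holds the lowest; its only neighbour, compound 1, sits well beyond the scatter above it, so compound 2 is the stronger inhibitor of the pair.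

The next compound, compound 3, is `C=C1C(=O)OC[C@@H]1CCOC(=O)Nc1ccc(Br)cc1`. Its relation to compound 2 is the following: the two compounds have the same atoms and bonds and differ only in configuration as drawn: 1 of 1 stereo elements differ; a stereocentre at a saturated ring carbon is drawn S in compound 2 and R in compound 3. For the measured compounds named here, no pair among the measured compounds isolates a change of configuration alone, since compound 1 differs from compound 2 both in its drawn configuration and in the group on the aromatic ring. The direction of this step in this assay is therefore open; a single reversed stereocentre can leave the number unchanged within the scatter or move it either way. Compound 3 is expected to give 600 nM, within 200 nM to 3000 nM, which corresponds to an expected step of a 1.7-fold higher number from compound 2 to compound 3 (0.23 log units; within the scatter).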

Compound 3, half-maximal inhibitory concentration: 720 nM
Beside the measured number, compound 3's estimate is 1.2-fold (0.08 log units) below it; measured number inside the range.
By their numbers in this assay, from the lowest: compound 2; then compounds 3 and 1 (each within the scatter of the next).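

In this assay, the stereocentre at the saturated ring carbon turns out to matter in its own right: going from S to R gives a 2.1-fold higher number from compound 2 to compound 3 (0.31 log units; beyond the scatter), a modest step that leaves the S form with the lower number of the bromo pair. This step can be assigned to that stereocentre alone because nothing else separates the two structures: the fact that compounds 2 and 3 differ only in the configuration as drawn. Among the compounds shown here, the R series also gives the first reading of the group on the aromatic ring, where bromo in place of butyl gives a 1.7-fold lower number from compound 1 to compound 3 (0.23 log units; within the scatter), so this exchange does not separate the two compounds at this configuration.

The compounds shown leave open whether the same reversal would give a step of similar size or direction with butyl on the aromatic ring, so the effect of configuration rests on the bromo pair alone. They also leave open how an amine, a carboxylic acid or a chain longer than butyl on the aromatic ring would read in this assay.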